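This account rests on a few compounds, and the source may have more. Where it says the series, first, only, none or still open, it means among the compounds named here.

Measured in an ADME assay on MRC5 cells (Homo sapiens) for antiproliferative activity, read by fluorescence and resazurin assay, with a stated time of 68 h; on this read-out lower numbers stand for an effect already at smaller amounts and higher numbers for an effect only at larger amounts of compound:
- Compound 1 `Cc1ccc(-c2cc(C(=O)NCCN3CCCC3)c3cc(Cl)ccc3n2)cc1` gives 7000 nM
- Compound 2 `CN1CCN(c2cc(C(=O)NCCN3CCCC3)c3cc(F)ccc3n2)CC1` gives 20000 nM
- Compound 3 `O=C(NCCN1CCCC1)c1cc(NCCC2CCOCC2)nc2ccc(F)cc12` gives > 50000 nM, a limit and not a number

Compound 3 therefore has no exact position in the series: the limit of > 50000 nM in this assay, at which 1 of the 3 values shown sits.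

Compound 4 `O=C(NCCN1CCCC1)c1cc(NCCC2CCOCC2)nc2ccc(Cl)cc12` follows from compound 3 by one change, chloro in place of fluoro on an aromatic carbon.

For the measured compounds named here, no measured step makes this exchange. Going by the values given here, the only measured step, an at least 2.5-fold higher number from compound 2 to compound 3 (0.39 log units; beyond the scatter), lies at another place and is beyond the scatter. It leads to the group that compound 3 and compound 4 share, so it favours a high number for compound 4. Among the compounds with values here, compound 1 is the only measured chloro compound and gives 7000 nM, but it also carries a different group at that other place, so it gives only weak support for a drop.

In this assay, a small step towards lower numbers is expected at most, and a result at the limit remains likely. The expected step is an at least 1.2-fold lower number from compound 3 to compound 4 (0.09 log units; that floor lies within the scatter). For compound 4 the estimate is 40000 nM. The estimated range for compound 4 runs from 15000 nM to 80000 nM.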

Compound 4, half-maximal effective concentration: 31000 nM
Beside the measured number, compound 4's estimate is 1.3-fold (0.11 log units) above it; the measured number falls inside the stated range.
By their numbers in this assay, from the lowest: compound 1; then compounds 2 and 4 (each within the scatter of the next). At a limit, above all of these: compound 3.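

In this assay, chloro in place of fluoro on this aromatic carbon gives the (2-(oxan-4-yl)ethyl)amino compounds a measured number, with an at least 1.6-fold lower number from compound 3 to compound 4 (0.20 log units; that floor lies within the scatter), so the size of the exchange is known only as a floor. Compound 3 stands at a limit and not a number: the limit of > 50000 nM in this assay, at which 1 of the 4 values shown sits. With chloro held fixed, the other place now has its own reading, a 4.4-fold higher number from compound 1 to compound 4 (0.65 log units; beyond the scatter), which sets (2-(oxan-4-yl)ethyl)amino on the side of higher numbers than 4-methylphenyl.

As far as these compounds go, whether the chloro for fluoro exchange carries over to compounds with 4-methylphenyl or 4-methylpiperazin-1-yl at the other place remains open. Also open, from the compounds shown here alone, is how bromo, methoxy or a nitrile on this aromatic carbon would read in this assay.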